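This account rests on a few compounds, and the source may have more. Where it says the series, first, only, none or still open, it means among the compounds named here.

Measured so far:
compound 1 `c1ccc(OCCCOc2cccc(-c3cc4ccc(C5=NCCN5)cc4o3)c2)cc1` with 10100 nM
compound 2 `N=C(N)c1ccc2cc(-c3cccc(OCCCCCCOc4ccccc4)c3)oc2c1` with 4300 nM

In an ADME assay on L6 cells (Rattus norvegicus) for cytotoxicity, read by resazurin assay, with a stated time of 70 h (a lower number here means a stronger inhibitor, a higher number a weaker inhibitor), compound 2 gives the lowest of the two numbers; its nearest neighbour is compound 1, whose number is higher by a gap beyond the usual scatter. For the measured compounds named here, the two compounds differ in more than one place, so no single step between them can be stated.

Compound 3 `c1ccc(OCCCCCCOc2cccc(-c3cc4ccc(C5=NCCN5)cc4o3)c2)cc1` is the next compound. It differs from compound 2 by a group of 5 heavy atoms (3 carbon, 2 nitrogen; one five-membered non-aromatic ring with 2 hetero atoms) in place of a group of 3 heavy atoms (1 carbon, 2 nitrogen; no ring), on an aromatic carbon, the new group carrying one five-membered non-aromatic ring with two hetero atoms and sitting on the six-membered carbon ring of the fused system, meta and para to the fused ring. Going by the values given here, with no single-change step available in this assay, the expected step from compound 2 to compound 3 in this assay is a 1.5-fold higher number from compound 2 to compound 3 (0.18 log units; within the scatter), a modest move toward a weaker number, hardly beyond the scatter. Compound 3 is thus estimated at 6500 nM, with a range from 2500 nM to 17000 nM.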

Compound 3, half-maximal inhibitory concentration: 1800 nM
Compound 3: the middle estimate sits 3.6-fold (0.56 log units) above what was measured; measured number outside the range, below it.
By their numbers in this assay, from the lowest: compound 3; then compound 2; then compound 1.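

In this assay, putting the group with one five-membered non-aromatic ring in place of the open-chain group on the aromatic carbon, with the rest of the structure unchanged, gives a 2.4-fold lower number from compound 2 to compound 3 (0.38 log units; beyond the scatter), so this position responds to the change of group beyond the scatter. With that ring group kept, 3-phenoxypropyl in place of phenoxy on the saturated chain carbon gives a 5.6-fold lower number from compound 1 to compound 3 (0.75 log units; beyond the scatter), which shows that the chain also moves the number, in the same direction. No measurement on hand accounts for either step.

Going by these compounds, it remains open whether an amine on that aromatic carbon would give a number near that of compound 2 or that of compound 3. On these data alone, whether a longer chain would lower the number further also remains open.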